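The source may hold more compounds than are shown below. What is called first, only, known or untested is meant among the compounds shown, and "the series" means these compounds.

Working notes on the series. In a functional assay on HT-29 cells (Homo sapiens) for antiproliferative activity, read by sulforhodamine B assay, with a stated time of 72 h (on this read-out lower numbers stand for stronger inhibition and higher numbers for weaker inhibition), compound 1 (`CCCCCCCCc1ccc(CCC(CO)(CO)NC(C)=O)c2ccccc12`) gives 36500 nM and compound 2 (`CCCCCCCCc1ccc(CCC(CO)(CO)NC(=O)CCC)c2ccccc12`) gives 26400 nM, so compound 2 stands level with compound 1 within the scatter. Compound 3 (`CCCCCCCCCCCCCC(=O)NC(CO)(CO)CCc1ccc(CCCCCCCC)c2ccccc12`) is reached from compound 2 through decyl in place of hydrogen on a saturated chain carbon, three bonds along the chain from a carbonyl carbon. For the measured compounds named here, only one measured step bears on this change: a 1.4-fold lower number from compound 1 to compound 2 (0.14 log units; within the scatter), with ethyl in place of hydrogen on a saturated chain carbon bound to a carbonyl carbon. That single step stays within the scatter and involves a much smaller group, so it gives only weak guidance. No step beyond the scatter is therefore expected in this assay, with any drift expected towards a lower number. The expected step is a 1.5-fold lower number from compound 2 to compound 3 (0.17 log units; within the scatter). For compound 3 the estimated value is 18000 nM, with an expected range of 6000 nM to 50000 nM.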

Compound 3, half-maximal inhibitory concentration: > 80000 nM
Compound 3: only a limit was reported; the forecaster's own chance of this, stated with the estimate: 15%; middle value at least 4.4-fold (0.64 log units) away from the limit.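

In this assay compound 3 is reported only as a limit: the limit of > 80000 nM in this assay, at which 1 of the 3 values shown sits. Even so, chain length at this position is not without consequence: decyl in place of hydrogen, three bonds along the chain from a carbonyl carbon, gives an at least 3.0-fold higher number from compound 2 to compound 3 (0.48 log units; beyond the scatter), whereas the small ethyl change gave a 1.4-fold lower number from compound 1 to compound 2 (0.14 log units; within the scatter). Read from the other amide, the step is an at least 2.1-fold higher number from compound 1 to compound 3 (0.34 log units; beyond the scatter), so the long chain moves the number upward from both shorter amides, by an amount the limit leaves unfixed.

Open, from the compounds shown here alone, is how a hexyl chain at this carbon would read, and so at what length the number starts to rise. Also open, going by these compounds, is whether an amine or a carboxylic acid at the end of a long chain would give the same upward step.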